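The compounds below may be only part of what the source reports. "The series", "measured", "known", "first", "only" and "open" are said of these compounds alone.

Measured compounds, cytotoxic activity on myeloma cells:

compound 1, `COc1cc(-c2cc(/C=C/C(=O)c3ccc(N)cc3)[nH]n2)cc(OC)c1OC`: -35%
compound 2, `COc1ccc(C(=O)/C=C/c2cc(-c3cc(OC)c(OC)c(OC)c3)n[nH]2)cc1OC`: -50%

In a functional assay on RPMI-8226 cells (Homo sapiens) for cytotoxicity, read by sulforhodamine B assay, with a stated time of 48 h, tested at 10 uM (a higher number here means a weaker effect of the compound at the concentration tested, a lower number a stronger effect), compound 2 stands lowest of the two numbers measured; its nearest neighbour is compound 1, which gives -35%. Among the measured compounds shown here, the only step recorded, a number 15 percentage points lower from compound 1 to compound 2 (beyond the scatter), changes the group on the carbonyl carbon and is modest, though beyond the scatter.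

Compound 3, `COc1cc(-c2cc(/C=C/C(=O)c3ccc(F)c(F)c3)[nH]n2)cc(OC)c1OC`, has not yet been measured. It differs from compound 2 by 3,4-difluorophenyl in place of 3,4-dimethoxyphenyl on a carbonyl carbon. For the measured compounds named here, no measured step swaps 3,4-dimethoxyphenyl for 3,4-difluorophenyl, so the one step at hand bears only loosely: it shows that exchanging the group on the carbonyl carbon moves the read-out by a modest amount. A step of similar size in either direction, or none beyond the scatter, is therefore plausible, and the estimate is set near compound 2 with a wide range.

Compound 3 is expected to give -42%, between -70% and -14%, which means an estimated step of a number 8 percentage points higher from compound 2 to compound 3 (within the scatter).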

Compound 3, a percentage reported as activity, at one concentration (the size of the read-out at that concentration, not a potency): -21%
The estimate for compound 3 lay 21 percentage points below the measured number, and the stated range covers the measured number.
By their numbers in this assay, from the lowest: compound 2; then compound 1; then compound 3.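

In this assay, the group on the carbonyl carbon proves to matter in both directions: a number 29 percentage points higher from compound 2 to compound 3 (beyond the scatter) with 3,4-difluorophenyl in place of 3,4-dimethoxyphenyl, and a number 14 percentage points higher from compound 1 to compound 3 (beyond the scatter) with 3,4-difluorophenyl in place of 4-aminophenyl. Among these three groups, the 3,4-difluorophenyl of compound 3 therefore gives the weakest effect at the concentration tested, with both of its steps beyond the scatter, so this position does not tolerate every aryl exchange equally. No measurement at hand accounts for this order.

Still open, as far as these compounds go, is whether both methoxy groups of compound 2 are needed, which a 4-methoxyphenyl or an unsubstituted phenyl on the carbonyl carbon would help settle. With one concentration in one cell line, the order says nothing about potency or about other cell types.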